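The source may hold more compounds than are shown below. What is called first, only, known or untested is meant among the compounds shown, and "the series" means these compounds.

Series notes, values in an ADME assay on MT4 cells (Homo sapiens) for cytotoxicity, read by MTT assay, with a stated time of 5 days; on this read-out lower numbers stand for higher toxicity in this test and higher numbers for lower toxicity in this test:

- compound 1 `N#Cc1ccc(Nc2nccc(OCc3cccc(Br)c3)n2)cc1`: 221000 nM
- compound 2 `Cc1ccccc1COc1ccnc(Nc2ccc(C#N)cc2)n1`: 12000 nM
- compound 3 `N#Cc1ccc(Nc2nccc(OCc3ccccc3C#N)n2)cc1`: 113000 nM

Compound 3 is second of the three numbers, but it lies within the scatter of compound 1. The gap to compound 2 is clear: a 9.4-fold higher number from compound 2 to compound 3 (0.97 log units; beyond the scatter).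

Compound 4 `N#Cc1ccc(COc2ccnc(Nc3ccc(C#N)cc3)n2)cc1` is the next case. It carries 4-cyanophenyl in place of 2-cyanophenyl on a saturated chain carbon bound to an oxygen on an aromatic ring.

Among the measured compounds shown here, no measured step compares these two groups directly, so the evidence is indirect. The swap of 3-bromophenyl for 2-cyanophenyl gave a 2.0-fold lower number from compound 1 to compound 3 (0.29 log units; within the scatter). Only the swap to 2-methylphenyl gave a large change: an 18-fold lower number from compound 1 to compound 2 (1.27 log units; beyond the scatter). Among these three compounds, the two without 2-methylphenyl sit together, and compound 2 stands apart. Compound 4 has no methyl and keeps the cyano group, so it is expected to stay with compound 1 and compound 3, although three compounds make a thin basis. No shift in either direction is expected beyond the scatter, and the estimated step is a 1.3-fold lower number from compound 3 to compound 4 (0.10 log units; within the scatter).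

The expected value for compound 4 is 90000 nM, with an estimated range of 25000 nM to 260000 nM.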

Compound 4, half-maximal cytotoxic concentration: 209000 nM
For compound 4 the middle estimate is 2.3-fold (0.37 log units) below the measured one; measured number inside the range.
By their numbers in this assay, from the lowest: compound 2; then compounds 3, 4 and 1 (each within the scatter of the next).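

Moving the nitrile from 2-cyanophenyl to 4-cyanophenyl on the saturated chain carbon gives the first direct read on this change in this assay: the two placements cannot be told apart (a 1.8-fold higher number from compound 3 to compound 4 (0.27 log units; within the scatter)), and 4-cyanophenyl cannot be told apart from 3-bromophenyl either (a 1.1-fold lower number from compound 1 to compound 4 (0.02 log units; within the scatter)). Among the compounds shown here, compounds 1, 3 and 4 now form a group of three with different substituents and different substitution patterns on this ring, while compound 2, with 2-methylphenyl, stays apart from the new compound as well (a 17-fold higher number from compound 2 to compound 4 (1.24 log units; beyond the scatter)), so the single low number in the set no longer rests on comparisons with only two neighbours. Nothing available explains why 2-methylphenyl differs from the other three groups.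

Still open, going by these compounds, is whether the low number of compound 2 goes with the methyl group itself or with its place on the ring, a question that 4-methylphenyl at this position would address. Also open, on these data alone, is how the read-out responds to an amine or a carboxylic acid on this ring, or to a longer chain in place of the single saturated carbon.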